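The source may report more compounds than this note shows. Statements on the series, on what has been measured and on what is new or still open speak of the compounds shown alone.

Measured so far in a functional assay on HCT-116 cells (Homo sapiens) for inhibition, read by MTT assay, with a stated time of 48 h, tested at 2 uM; a higher number here means more inhibition at the concentration tested (going by the name of the read-out), a lower number less inhibition:
compound 1, `Cc1noc(C)c1-c1ccc2c(c1)C(c1ccccc1)N(Cc1nnc(-c3ccccc3)o1)C(=O)N2C`, 31.4%;
compound 2, `Cc1noc(C)c1-c1ccc2c(c1)C(c1ccccc1)N(Cc1nc(-c3ccccc3)cs1)C(=O)N2C`, 26.7%.

Compound 2 and compound 1 share a core and differ only in the group on the saturated chain carbon bound to the amide-type nitrogen in the ring. Going by the values given here, their two numbers lie within the scatter of each other, the only measured step being a number 4.7 percentage points lower from compound 1 to compound 2 (within the scatter), so nothing separates them in this assay.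

Compound 3, `Cc1noc(C)c1-c1ccc2c(c1)C(c1ccccc1)N(Cc1nc(-c3ccc(F)cc3)cs1)C(=O)N2C`, differs from compound 2 by fluoro in place of hydrogen on an aromatic carbon. Among the compounds with values here, the one measured step concerns the replacement of a heteroaryl group and bears at best loosely on a change at the phenyl that sits on the thiazole. Within the data shown here, the single measured step was within the scatter, and there is no measurement of a fluoro in place of hydrogen on an aromatic carbon, so no step beyond the scatter is expected in this assay ; the expected step is a number 0.3 percentage points higher from compound 2 to compound 3 (within the scatter). Compound 3 is therefore estimated at 27%, with a range from 15% to 40%.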

Compound 3, a percentage reported as inhibition, at one concentration (the size of the read-out at that concentration, not a potency): 33.3%
Beside the measured number, compound 3's estimate is 6.3 percentage points below it; measured number inside the range.
By their numbers in this assay, from the lowest: compounds 2, 1 and 3 (each within the scatter of the next).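

The fluoro in compound 3 is the first change shown on the phenyl that sits on the thiazole, and in this assay it gives a number 6.6 percentage points higher from compound 2 to compound 3 (within the scatter), so this place para to a large group accepts a fluorine with no step beyond the scatter. The comparison with the oxadiazole-bearing compound gives a number 1.9 percentage points higher from compound 1 to compound 3 (within the scatter), so the 4-(4-fluorophenyl)-1,3-thiazol-2-yl group and the 5-phenyl-1,3,4-oxadiazol-2-yl group cannot be told apart at this single concentration. Nothing available explains these numbers.

On these data alone, it remains open whether an amine or a carboxylic acid at this place on the phenyl would move the number beyond the scatter. Also open, as far as these compounds go, is what a longer chain between the amide-type nitrogen and the heteroaryl group would do.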